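Amide variation and tolerability: notes on compounds 1 to 4

The compounds below may be only part of what the source reports. "The series", "measured", "known", "first", "only" and "open" are said of these compounds alone.

Compound 1 `Cc1ccccc1-c1cnc(NC(=O)c2ccc(F)cc2)n1C`; in a toxicity assay on THP-1 cells (Homo sapiens) for inhibition (a lower number here means that less compound is tolerated, a higher number that more compound is tolerated), compound 1 gives > 50000 nM, a limit of the assay, not a number.
Compound 2 `COc1ccc(-c2cnc(NC(=O)c3ccccn3)n2C)cc1`; in this assay compound 2 gives > 100000 nM, likewise a limit.
Compound 3 `Cn1c(-c2ccccc2)cnc1NC(=O)c1cccc(Cl)c1`; in this assay compound 3 gives > 50000 nM, also a limit.

Compound 2 therefore stands at a limit only, and the two other values are limits as well: the limit of > 100000 nM in this assay, at which 1 of the 3 values shown sits; (the limit of > 50000 nM in this assay, at which 2 of the 3 values shown sit). For the measured compounds named here, no step between measured compounds is available.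

Compound 4 `CCC(=O)Nc1ncc(-c2ccc(OC)cc2)n1C` differs from compound 2 in one place: ethyl in place of pyridin-2-yl on a carbonyl carbon. With every value shown resting at a limit, the step expected from this change is a number no higher from compound 2 to compound 4 (the limit leaves the size open), none beyond the scatter. Compound 4 is estimated at 100000 nM, range 30000 nM to 300000 nM, most probably reported once more as a limit rather than a number.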

Compound 4, half-maximal cytotoxic concentration: > 100000 nM
Compound 4: a limit, no number; the forecaster's own chance of this, stated with the estimate: 85%; the middle value sits exactly at the limit.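

In this assay compound 2 and compound 4 both rest at limits, and no step can be read between them. The compounds shown leave open whether the group on the carbonyl carbon changes tolerance at all: none of the four values is a number.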